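This account rests on a few compounds, and the source may have more. Where it says the series, first, only, none or still open, it means among the compounds named here.

Measured compounds:
- compound 2 `CN(C[C@H]1Cc2c(cccc2N2C[C@@H]3C[C@H]2CN3)CN1)[C@H]1CCCc2cccnc21` gives 100% in an ADME assay on microsomes from liver (Homo sapiens) for metabolic stability, read by LC-MS, with a stated time of 10 min; a higher number here means that more of the compound is left, a lower number that less of the compound is left
- compound 3 `CN1CCN(c2cccc3c2C[C@H](CN(C)[C@H]2CCCc4cccnc42)N(C)C3)CC1` gives 83.3% in this assay
- compound 1 `Cc1cnc(CN(C)C[C@H]2Cc3c(cccc3N3CCNCC3)CN2)c(C)c1` gives "not determined" (no result reported) in this assay

Of the two numbers in hand, compound 2 stands highest; compound 3 lies below it by a gap beyond the usual scatter, and compound 1 adds no number. Compound 4 `CN(C[C@H]1Cc2c(cccc2N2C[C@H]3C[C@@H]2CN3)CN1)[C@H]1CCCc2cccnc21` differs from compound 2 only in how it is drawn in space: the two compounds have the same atoms and bonds and differ only in configuration as drawn: 2 of 4 stereo elements differ; a stereocentre at a saturated ring carbon is drawn S in compound 2 and R in compound 4; a stereocentre at a saturated ring carbon is drawn S in compound 2 and R in compound 4. For the measured compounds named here, no step between measured compounds is recorded, so nothing in hand shows how such a change alters the result. Stereochemistry alone often leaves this kind of read-out close to unchanged, so the expected step from compound 2 to compound 4 is a number 6 percentage points lower from compound 2 to compound 4 (within the scatter), within the scatter or slightly downward. Compound 4 is therefore estimated at 94%, with a range from 78% to 100%.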

Compound 4, percent of the compound remaining: 100%
Compound 4: the middle estimate sits 6 percentage points below what was measured; measured number inside the range.
By their numbers in this assay, from the lowest: compound 3; then compounds 2 and 4 (each within the scatter of the next).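

In this assay the step is no change at the digits printed from compound 2 to compound 4 (within the scatter). This is the first comparison in hand between compounds that differ in one respect, and it shows that inverting these two stereocentres at saturated ring carbons leaves the amount of compound remaining unmoved at this time point: the fact that compounds 2 and 4 differ only in the configuration as drawn

The pair says nothing about how the read-out responds when atoms rather than configuration change at this part of the molecule, for example when an acetyl group is added there. It also leaves open whether the same indifference to configuration would hold on a longer incubation.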